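Arylpiperazine series: naphthyl replacement at the ring nitrogen

The source may report more compounds than this note shows. Statements on the series, on what has been measured and on what is new or still open speak of the compounds shown alone.

Of the compounds shown here, three have been measured in a functional assay on CHO cells with adenosine receptor A1 (Homo sapiens) as the target, read by cAMP accumulation and immunoassay, with a stated time of 6 min, tested at 0.01 uM; a lower number here means a stronger effect, a higher number a weaker effect of the compound at the concentration tested. Compound 1 `COc1ccc(N2CCN(Cc3csc(N)c3C(=O)c3ccc(Cl)cc3)CC2)cc1` gives -1.2%. Compound 2 `Nc1scc(CN2CCN(c3ccc(Cl)c(C(F)(F)F)c3)CC2)c1C(=O)c1ccc(Cl)cc1` gives -2.5%, and compound 3 `Nc1scc(CN2CCN(c3ccc(OC(F)(F)F)cc3)CC2)c1C(=O)c1ccc(Cl)cc1` gives 0%. All three numbers sit within the scatter of one another; compound 3 lies nearest to compound 1 and furthest from compound 2, and neither gap is beyond the scatter.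

Compound 4 `Nc1scc(CN2CCN(c3cccc4ccccc34)CC2)c1C(=O)c1ccc(Cl)cc1` is the next member and has not been measured. It differs from compound 3 in one place: naphthalen-1-yl in place of 4-(trifluoromethoxy)phenyl on an amine nitrogen in a ring.

Among the compounds with values here, two measured steps bear on this change, as both swap the group on the same amine nitrogen in the ring. a number 1.3 percentage points lower from compound 1 to compound 2 (within the scatter) and a number 2.5 percentage points higher from compound 2 to compound 3 (within the scatter). Neither step reaches beyond the scatter, so exchange of the aryl group at this position has so far left the read-out in this assay unchanged within the scatter. The remaining step, a number 1.2 percentage points higher from compound 1 to compound 3 (within the scatter), is likewise within the scatter. On this basis no step beyond the scatter is expected for compound 4. The expected step is no change at the digits printed from compound 3 to compound 4 (within the scatter). Compound 4 is estimated to give 0% in this assay, with a range from -10% to 10%.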

Compound 4, a percentage reported as activity, at one concentration (the size of the read-out at that concentration, not a potency): 8.7%
Beside the measured number, compound 4's estimate is 8.7 percentage points below it, and the stated range covers the measured number.
By their numbers in this assay, from the lowest: compounds 2, 1, 3 and 4 (each within the scatter of the next, the first and the last beyond it).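

In this assay, within the data shown here, naphthalen-1-yl on the amine nitrogen in the ring gives the first exchange at this position that passes the scatter, with a number 11.2 percentage points higher from compound 2 to compound 4 (beyond the scatter) as a modest step, while the other two exchanges stay inside it, with a number 8.7 percentage points higher from compound 3 to compound 4 (within the scatter) and a number 9.9 percentage points higher from compound 1 to compound 4 (within the scatter) as their printed steps. The aryl group here is therefore not wholly without bearing on the read-out, but the finding rests on one pair: naphthalen-1-yl separates from 4-chloro-3-(trifluoromethyl)phenyl and from neither 4-(trifluoromethoxy)phenyl nor 4-methoxyphenyl, so compound 3 and compound 1 go against any general separation of naphthalen-1-yl from the single-ring groups. Nothing available gives a reason for this step.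

The compounds shown leave open whether the step belongs to naphthalen-1-yl in particular or would also appear with naphthalen-2-yl or a quinolinyl group on the same nitrogen. They also leave open how a non-aromatic group such as cyclohexyl, or a phenyl ring carrying a carboxylic acid or an amine, would read at this position.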